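Moving from a 2-Bromophenyl to a 4-Nitrophenyl Amide

This account rests on a few compounds, and the source may have more. Where it says the series, first, only, none or still open, it means among the compounds named here.

Three amides sharing the core of compound 1 have been measured so far:

Compound 1, `O=C(CSc1nc(Nc2ccccc2)c2ccccc2n1)Nc1ccccc1Br`, gives 19800 nM in a functional assay on PC-3 cells (Homo sapiens) for inhibition, read by MTT assay, with a stated time of 72 h; a higher number here means a weaker inhibitor, a lower number a stronger inhibitor.
Compound 2, `O=C(CSc1nc(Nc2ccccc2)c2ccccc2n1)Nc1cccc(F)c1`, gives 15600 nM in this assay.
Compound 3, `O=C(CSc1nc(Nc2ccccc2)c2ccccc2n1)Nc1ccc(Br)cc1`, gives 8450 nM in this assay.

Compound 1 carries the highest of the three numbers. Its nearest neighbour is compound 2, with a 1.3-fold lower number from compound 1 to compound 2 (0.10 log units; within the scatter), a step that stays within the scatter. Its furthest is compound 3, with a 2.3-fold lower number from compound 1 to compound 3 (0.37 log units; beyond the scatter), a modest step beyond the scatter. Between compound 2 and compound 3 there is a 1.8-fold lower number from compound 2 to compound 3 (0.27 log units; within the scatter).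

Compound 4, `O=C(CSc1nc(Nc2ccccc2)c2ccccc2n1)Nc1ccc([N+](=O)[O-])cc1`, has not yet been measured. It differs from compound 1 in one place: 4-nitrophenyl in place of 2-bromophenyl on an amide-type nitrogen.

For the measured compounds named here, the step that bears most directly on this change is the one from compound 1 to compound 3, where a bromine on the same kind of ring was carried on a 4-bromophenyl instead of a 2-bromophenyl and the number fell modestly. Going by the values given here, no measured step introduces a nitro group, so the size of any further effect is unknown. On the strength of a 2.3-fold lower number from compound 1 to compound 3 (0.37 log units; beyond the scatter) alone, a modest lowering of the number is expected for compound 4, about a 2.0-fold lower number from compound 1 to compound 4 (0.30 log units; within the scatter). The estimate for compound 4 is 10000 nM, within a range from 4000 nM to 25000 nM.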

Compound 4, half-maximal inhibitory concentration: 25000 nM
Compound 4: middle estimate off by 2.5-fold (0.40 log units), on the low side; measured number inside the range.
By their numbers in this assay, from the lowest: compounds 3, 2, 1 and 4 (each within the scatter of the next, the first and the last beyond it).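

In this assay, the new result shows that the group carried on the ring matters, and not only where it sits: with nitro in place of bromo there is a 3.0-fold higher number from compound 3 to compound 4 (0.47 log units; beyond the scatter) and so the lower number of compound 3 does not carry over to every group on the phenyl ring of the amide. Against the other two amides the 4-nitrophenyl group cannot be told apart, since a 1.3-fold higher number from compound 1 to compound 4 (0.10 log units; within the scatter) and a 1.6-fold higher number from compound 2 to compound 4 (0.20 log units; within the scatter) both stay within the scatter, which leaves compound 3 as the only one of the series that separates from compound 4. Nothing available here explains why nitro and bromo part in this way.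

The compounds shown leave open whether the 4-bromophenyl amide of compound 3 is a special case, or whether other groups on that phenyl ring, such as an amine, a methoxy group or a carboxylic acid, would stand with compound 3 or with compound 4. As far as these compounds go, they also vary only the ring on the amide-type nitrogen, so what a change elsewhere in the shared core would do to these numbers remains unknown.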